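The source may hold more compounds than are shown below. What is called first, only, known or untested is meant among the compounds shown, and "the series" means these compounds.

Measured in a functional assay on DWD cells (Homo sapiens) for inhibition, read by sulforhodamine B assay; on this read-out lower numbers stand for stronger inhibition of growth and higher numbers for weaker inhibition of growth:
Compound 1 `Oc1ccc(-c2ccc(-c3ccc(-c4nc5ccccc5[nH]4)cc3)cc2)cc1`: 46300 nM
Compound 2 `COc1ccc(-c2ccc(-c3ccc(-c4nc5ccccc5[nH]4)cc3)cc2)cc1`: 100000 nM

Of these two compounds, compound 2 has the higher number, 100000 nM, and is the weaker growth inhibitor. For the measured compounds named here, the one measured step is a 2.2-fold higher number from compound 1 to compound 2 (0.33 log units; beyond the scatter), with methyl in place of hydrogen on an oxygen on an aromatic ring.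

Compound 3 `Clc1cccc(-c2ccc(-c3ccc(-c4nc5ccccc5[nH]4)cc3)cc2)c1` carries 3-chlorophenyl in place of 4-methoxyphenyl on an aromatic carbon, para to a large group: 3-chlorophenyl in place of 4-methoxyphenyl on an aromatic carbon. The measured step bears on this change only in part. Going by the values given here, it alters the same terminal group, but it replaces no ring and involves no chlorine, and no measured compound carries 3-chlorophenyl. Among the compounds with values here, its modest size, a 2.2-fold higher number from compound 1 to compound 2 (0.33 log units; beyond the scatter), is the only guide in this assay, so a step of no greater size is expected, leaning towards a lower number, and possibly none beyond the scatter. The expected change is a 1.7-fold lower number from compound 2 to compound 3 (0.22 log units; within the scatter). The estimated value for compound 3 is 60000 nM. The expected range for compound 3 runs from 25000 nM to 130000 nM.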

Compound 3, concentration for 50% growth inhibition: 100000 nM
Compound 3: the middle estimate sits 1.7-fold (0.22 log units) below what was measured; low and high end bracket the measured number.
By their numbers in this assay, from the lowest: compound 1; then compounds 2 and 3 (each within the scatter of the next).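

In this assay, the replacement of 4-methoxyphenyl by 3-chlorophenyl on this aromatic carbon, para to a large group, gives no change at the digits printed from compound 2 to compound 3 (within the scatter), so two groups that differ in their heteroatom and in their count of hydrogen-bond acceptors cannot be told apart at this position. Set against the 4-hydroxyphenyl group, the same 3-chlorophenyl group gives a 2.2-fold higher number from compound 1 to compound 3 (0.33 log units; beyond the scatter), which leaves compound 1 alone with the lowest number of the three and shows that a second, quite different group lands where the methyl ether did. No measurement shown here offers an explanation for why these two groups read alike or why the 4-hydroxyphenyl group stands apart.

The compounds shown leave open whether an amine or a carboxylic acid on this phenyl group would match compound 1, go beyond it, or read like compounds 2 and 3. They also leave open whether an unsubstituted phenyl group or a fluorine in place of the chlorine would read any differently from the 3-chlorophenyl group.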